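Diethylsulfamoyl in place of diethylcarbamoyl: compound 3 to compound 4

A few compounds are considered here, and "the series" means these few. Any claim that something is new, unique, unknown or untested is made for them only; others in the source may bear on it.

Measured in a functional assay on MIA PaCa-2 cells (Homo sapiens) for inhibition, read by MTT assay, with a stated time of 3 days; on this read-out lower numbers stand for stronger inhibition and higher numbers for weaker inhibition:
Compound 1 `CCN(CC)S(=O)(=O)c1ccc(S(=O)(=O)N2CCC[C@@H](C(=O)NC3COC3)C2)cc1`: > 10000 nM
Compound 2 `CCOC(=O)[C@@H]1C[C@H](O)CN(S(=O)(=O)c2ccc(S(=O)(=O)N(CC)CC)cc2)C1`: > 10000 nM
Compound 3 `CCN(CC)C(=O)c1ccc(S(=O)(=O)N2CCC[C@@H](C(=O)N3CCN(c4nc(C(C)C)no4)CC3)C2)cc1`: > 10000 nM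

Each of these three entries is a limit of the assay and not a number. Within the data shown here, compound 3 therefore gives only a limit, and the series so far stands at the limit of > 10000 nM in this assay, at which 3 of the 3 values shown sit, with no true number among its members.

Compound 4 `CCN(CC)S(=O)(=O)c1ccc(S(=O)(=O)N2CCC[C@@H](C(=O)N3CCN(c4nc(C(C)C)no4)CC3)C2)cc1` differs from compound 3 in one place: diethylsulfamoyl in place of diethylcarbamoyl on an aromatic carbon, para to a large group (diethylsulfamoyl in place of diethylcarbamoyl on an aromatic carbon). Among the measured compounds shown here, compound 1 and compound 2 also carry diethylsulfamoyl, but neither shares the rest of compound 3, and no measured pair isolates this change.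

The expected step, an at least 5.0-fold lower number from compound 3 to compound 4 (0.69 log units; beyond the scatter), points toward stronger inhibition in this assay, though its size is poorly fixed and a further limit remains quite possible. For compound 4 the estimate is 2000 nM, with an expected range from 150 nM to 10000 nM.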

Compound 4, half-maximal inhibitory concentration: > 10000 nM
Compound 4 gave a limit, no number; the forecaster's own chance of this, stated with the estimate: 40%; at least 5.0-fold (0.69 log units) between middle value and limit.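

Compound 3 and compound 4 both give only a limit in this assay, not a number, so no step can be read between them. The compounds shown leave open whether diethylsulfamoyl in place of diethylcarbamoyl changes inhibition at all, and which structure would give a true number, since the series stands entirely at one limit: the limit of > 10000 nM in this assay, at which 4 of the 4 values shown sit.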